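A few compounds are considered here, and "the series" means these few. Any claim that something is new, unique, unknown or untested is made for them only; others in the source may bear on it.

In an ADME assay on Caco-2 cells (Homo sapiens) for permeability, read by LC-MS, in the apical to basolateral direction, with a stated time of 60 min, at pH 6.5 (on this read-out lower numbers stand for lower permeability and higher numbers for higher permeability), compound 1 `CC(C)(C)[C@@H](O)C(=O)N1C[C@@H]2C[C@@H]2[C@H]1C(=O)NCc1cc(Cl)ccc1-n1cnnn1` gives 17 10^-6 cm/s and compound 2 `CC(C)(C)C[C@@H](O)C(=O)N1[C@@H]2C[C@@H]2C[C@H]1C(=O)NCc1cc(Cl)ccc1-n1cnnn1` gives 24 10^-6 cm/s, two values within the usual scatter of each other. Compound 3 `CC(C)(C)[C@@H](O)C(=O)N1C[C@H]2C[C@H]2[C@H]1C(=O)NCc1cc(Cl)ccc1-n1cnnn1` gives 3.8 10^-6 cm/s, so compound 1 stands with compound 2 and clear of compound 3. Going by the values given here, that gap is the only step measured between compounds differing in one place, a 4.5-fold lower number from compound 1 to compound 3 (0.65 log units; beyond the scatter), and it comes with the fact that compounds 1 and 3 differ only in the configuration as drawn. Compound 4 `O=C(NCc1cc(Cl)ccc1-n1cnnn1)[C@@H]1[C@H]2C[C@H]2CN1C(=O)[C@H](O)C1CCCCC1` has cyclohexyl in place of tert-butyl on a saturated chain carbon bound to a carbonyl carbon and an oxygen on a saturated carbon. Among the compounds with values here, no measured step touches this group, and the one step available concerns configuration alone, so it sets no size for this exchange. No shift beyond the scatter is therefore expected in this assay, and the expected step is a 1.1-fold lower number from compound 1 to compound 4 (0.05 log units; within the scatter). For compound 4 the estimated value is 15 10^-6 cm/s, with an expected range of 6 10^-6 cm/s to 35 10^-6 cm/s.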

Compound 4, apparent permeability: 25 10^-6 cm/s
Compound 4: middle estimate off by 1.7-fold (0.22 log units), on the low side, within the range that was stated.
By their numbers in this assay, from the lowest: compound 3; then compounds 1, 2 and 4 (each within the scatter of the next).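

In this assay, going by these compounds alone, cyclohexyl in place of tert-butyl on a saturated chain carbon bound to a carbonyl carbon and an oxygen on a saturated carbon gives a 1.5-fold higher number from compound 1 to compound 4 (0.17 log units; within the scatter), the first measured step at this position. On the core of compound 1, then, an open branched group and a six-membered carbon ring read alike at this place, although this single pair sets no rule for other groups. The only step beyond the scatter remains a 4.5-fold lower number from compound 1 to compound 3 (0.65 log units; beyond the scatter), and what stands with it is a different kind of change: the fact that compounds 1 and 3 differ only in the configuration as drawn

Going by these compounds, whether a group carrying a heteroatom at this place, such as an amine or a carboxylic acid, would also stay within the scatter remains open. So does whether cyclohexyl would read the same on the configuration of compound 3.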